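This account rests on a few compounds, and the source may have more. Where it says the series, first, only, none or still open, it means among the compounds named here.

Compound 1 `Cc1ccc(-c2c(C)nn(-c3nc(-c4ccc(Cl)c(Cl)c4)c(SC(C)C)s3)c2C(=O)O)cc1` is measured in a functional assay on BJAB cells (Homo sapiens) for antiproliferative activity, with a stated time of 4 days (on this read-out higher numbers stand for an effect only at larger amounts of compound and lower numbers for an effect already at smaller amounts), where compound 1 gives 3800 nM, the highest of the two numbers available. Among the measured compounds shown here, its only neighbour is compound 2 `Cc1cc(C)cc(-c2c(C)nn(-c3nc(-c4ccc(Cl)c(Cl)c4)c(SC(C)C)s3)c2C(=O)O)c1`, which in this assay gives 2700 nM; the step of a 1.4-fold lower number from compound 1 to compound 2 (0.15 log units; within the scatter) shows that a second methyl on that aryl ring leaves the number essentially unchanged. The unmeasured compound 3 `Cc1cc(-c2c(C)nn(-c3nc(-c4ccc(Cl)c(Cl)c4)c(SC(C)C)s3)c2C(=O)O)cc(C)n1` differs from compound 1 at the same position, (2,6-dimethylpyridin-4-yl in place of 4-methylphenyl on an aromatic carbon). For the measured compounds named here, the single measured step that touches this position stayed within the scatter, and nothing among the measured compounds shows what a ring nitrogen there does. The step of a 1.1-fold lower number from compound 1 to compound 3 (0.04 log units; within the scatter) is therefore expected to be small, with no clear direction. The value of compound 3 in this assay is estimated at 3500 nM, with a range from 1200 nM to 11000 nM.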

Compound 3, half-maximal effective concentration: 580 nM
The estimate for compound 3 lay 6.0-fold (0.78 log units) above the measured number; measured number below the stated range.
By their numbers in this assay, from the lowest: compound 3; then compounds 2 and 1 (each within the scatter of the next).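

In this assay, the aromatic carbon of the five-membered ring proves sensitive to the group it carries: the change to 2,6-dimethylpyridin-4-yl gives a 6.6-fold lower number from compound 1 to compound 3 (0.82 log units; beyond the scatter) from 4-methylphenyl and a 4.7-fold lower number from compound 2 to compound 3 (0.67 log units; beyond the scatter) from 3,5-dimethylphenyl. The second step is the closer comparison, since the substituent names differ mainly in the ring nitrogen, and both new steps lie beyond the scatter, whereas the earlier change from 4-methylphenyl to 3,5-dimethylphenyl did not. Among these three compounds, the lower number therefore goes with the ring nitrogen, but nothing available explains this result.

The compounds shown leave open whether the methyl groups are needed alongside the ring nitrogen, as they include neither an unsubstituted pyridin-4-yl nor a 2-methylpyridin-4-yl at this position. They also leave open whether the step would persist with an amide in place of the carboxy group.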